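The compounds below may be only part of what the source reports. "The series", "measured", "known", "first", "only" and "open" are said of these compounds alone.

Compound 1 `CN(C)CCCN1CCN(CC(=O)Nc2ccc(-c3nc4cc(F)ccc4o3)cc2)CC1` gives 2590 nM in a functional assay on HT-29 cells (Homo sapiens) for cytotoxicity, read by MTT assay, with a stated time of 24 h (on this read-out higher numbers stand for weaker inhibition and lower numbers for stronger inhibition), the lowest of the two numbers measured. Within the data shown here, its single measured neighbour, compound 2 `CN(C)CCN1CCN(CC(=O)Nc2ccc(-c3nc4cc(F)ccc4o3)cc2)CC1`, gives 8190 nM in this assay, a change of a 3.2-fold higher number from compound 1 to compound 2 (0.50 log units; beyond the scatter) for dimethylamino in place of (dimethylamino)methyl on the chain. Compound 3 `CN(C)CCCN1CCN(CC(=O)Nc2ccc(-c3nc4ccccc4o3)cc2)CC1` differs from compound 1 elsewhere: hydrogen in place of fluoro on an aromatic carbon. Among the measured compounds shown here, no measured step touches the fused ring system, so the one known step, a 3.2-fold higher number from compound 1 to compound 2 (0.50 log units; beyond the scatter), offers no guide to this change. A step of a 1.4-fold higher number from compound 1 to compound 3 (0.13 log units; within the scatter) is therefore expected, within or near the scatter. The estimate for compound 3 in this assay is 3500 nM, ranging from 1500 nM to 8000 nM.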

Compound 3, half-maximal inhibitory concentration: 10600 nM
Estimate against measurement, compound 3: 3.0-fold (0.48 log units) below; the whole stated range lies below it.
By their numbers in this assay, from the lowest: compound 1; then compounds 2 and 3 (each within the scatter of the next).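

In this assay the aromatic carbon carrying the fluoro proves to be a position that counts: going from 5-fluoro-1,3-benzoxazol-2-yl to 1,3-benzoxazol-2-yl gives a 4.1-fold higher number from compound 1 to compound 3 (0.61 log units; beyond the scatter) and so costs activity, a step beyond the scatter. Among the compounds shown, the chain is thus not the only part of compound 1 whose change raises the number. Nothing measured here explains why the fluoro has this effect.

On these data alone, whether chloro, methoxy or trifluoromethyl on this carbon would match the fluoro remains open. So does whether a fluoro on another carbon of the fused system would give the same result.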